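Chloro in Place of Hydrogen: Compound 2 to Compound 3

A few compounds are considered here, and "the series" means these few. Any claim that something is new, unique, unknown or untested is made for them only; others in the source may bear on it.

Measured compounds:
Compound 1, `CC1=CC[C@@H]([C@@](C)(O)CCCC(C)(C)NC(=S)NN)CC1`: 29000 nM
Compound 2, `CC1=CC[C@@H]([C@@](C)(O)CCCC(C)(C)NC(=S)N/N=C\c2ccccc2)CC1`: 23800 nM

In a functional assay on NCI/ADR cells (Homo sapiens) for cytotoxicity, read by sulforhodamine B assay (on this read-out higher numbers stand for weaker inhibition of growth and lower numbers for stronger inhibition of growth), compound 1 gives 29000 nM. In this assay, going by the values given here, compound 2 gives 23800 nM, the lowest of the two numbers, though its only neighbour, compound 1, lies within the scatter of it, so no order between them can be claimed. Among the compounds with values here, the one measured step, a 1.2-fold lower number from compound 1 to compound 2 (0.09 log units; within the scatter), is within the scatter as well.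

Compound 3, `CC1=CC[C@@H]([C@@](C)(O)CCCC(C)(C)NC(=S)N/N=C\c2ccc(Cl)cc2)CC1`, has not yet been measured. It differs from compound 2 by chloro in place of hydrogen on an aromatic carbon. Within the data shown here, no measured step concerns a change of this kind, and the only step available, which replaced a nitrogen atom with a larger group, did not move the number beyond the scatter. On that basis the step of a 1.3-fold lower number from compound 2 to compound 3 (0.12 log units; within the scatter) is expected to stay within the scatter. Compound 3 is therefore estimated at 18000 nM, in the range 7000 nM to 45000 nM.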

Compound 3, concentration for total growth inhibition: 36400 nM
Compound 3: the middle estimate sits 2.0-fold (0.31 log units) below what was measured; low and high end bracket the measured number.
By their numbers in this assay, from the lowest: compounds 2, 1 and 3 (each within the scatter of the next).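

In this assay, chloro in place of hydrogen on an aromatic carbon, para to a large group, gives a 1.5-fold higher number from compound 2 to compound 3 (0.18 log units; within the scatter) and so produces no readable change at this position. Measured against the shared core without the ring, the whole 4-chlorophenyl-bearing group gives a 1.3-fold higher number from compound 1 to compound 3 (0.10 log units; within the scatter) and, like the phenyl-bearing group before it, stays within the scatter, so the three compounds cannot be put in any order. Nothing available bears on why chloro leaves the number within the scatter here.

On these data alone, whether another group on this aromatic carbon, such as an amine, a methoxy group or a carboxylic acid, would move the number beyond the scatter remains open. Also open, as far as these compounds go, is whether a second chloro on the ring, or a longer chain in place of the ring-bearing group, would do so.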